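Swapping the Benzyl on the Core Nitrogen for Methoxyphenyl

This account rests on a few compounds, and the source may have more. Where it says the series, first, only, none or still open, it means among the compounds named here.

Compound 1 `Cc1cc(C(=O)Nc2cc(Cl)cc(Cl)c2)nn1Cc1ccccc1` carries a benzyl group on one ring nitrogen of its core. In an assay on HEK293 cells for binding affinity to Neuropeptide Y receptor type 5 (Homo sapiens), read by radioligand binding (on this read-out higher numbers stand for weaker inhibition and lower numbers for stronger inhibition), compound 1 gives > 1000 nM, which is a limit of the assay rather than a number. Compound 2 `Cc1cc(C(=O)Nc2cc(Cl)cc(Cl)c2)nn1-c1ccccc1C(F)(F)F` carries instead a phenyl ring with a trifluoromethyl group, attached directly to that nitrogen. In this assay compound 2 gives > 1000 nM, again a limit and not a number. Taken together, what the measurements show is the limit of > 1000 nM in this assay, at which 2 of the 2 values shown sit, so compound 1 cannot be placed against any real number; it simply stands at the limit.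

Compound 3 `COc1cccc(-n2nc(C(=O)Nc3cc(Cl)cc(Cl)c3)cc2C)c1` differs from compound 1 by 3-methoxyphenyl in place of benzyl on an aromatic nitrogen. Among the measured compounds shown here, no step between measured compounds exists to set a size for such a change, and the one compound with a directly attached phenyl ring, compound 2, returned only a limit. Compound 3 is therefore expected to stay weak, and the step that the limit leaves unreadable from compound 1 to compound 3 is expected to be none beyond the scatter. Compound 3 is estimated at 3000 nM, within a range from 700 nM to 20000 nM, with a good chance that only a limit is reported again.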

Compound 3, half-maximal inhibitory concentration: > 1000 nM
Compound 3: only a limit was reported; the forecaster's own chance of this, stated with the estimate: 70%; the middle value does not contradict the limit.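

In this assay compound 3 gives > 1000 nM, which is a limit and not a number. Among the compounds shown here, compound 1 also stands at a limit, so no step from benzyl to 3-methoxyphenyl can be read between compound 1 and compound 3. All the results so far share one outcome: the limit of > 1000 nM in this assay, at which 3 of the 3 values shown sit. The compounds shown leave open which change to the shared core would give a real number instead of a limit.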